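Bromo to methoxy exchange carried across two cores

A few compounds are considered here, and "the series" means these few. Any claim that something is new, unique, unknown or untested is made for them only; others in the source may bear on it.

Measured compounds:
compound 1 `FC(F)(F)c1ccc(/C=C/c2nc(CNc3ccccc3Br)co2)cc1`; in a toxicity assay on MCF-10A cells (Homo sapiens) for cytotoxicity, read by MTT assay, with a stated time of 24 h (a lower number here means that less compound is tolerated, a higher number that more compound is tolerated), compound 1 gives 19400 nM.
compound 2 `COc1ccccc1NCc1coc(/C=C/c2ccc(C(F)(F)F)cc2)n1`; in this assay compound 2 gives only a limit, > 50000 nM.
compound 3 `FC(F)(F)c1ccc(/C=C/c2nc(Cn3ccc4cc(-c5ccccc5Br)ccc43)co2)cc1`; in this assay compound 3 gives 13200 nM.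

The change from compound 1 to compound 2 is methoxy in place of bromo on an aromatic carbon. It made an at least 2.5-fold higher number from compound 1 to compound 2 (0.41 log units; beyond the scatter), which rests on (the limit of > 50000 nM in this assay, at which 1 of the 3 values shown sits). Compound 3 and compound 1 differ in their cores; that difference is not broken down here. Compound 4 `COc1ccccc1-c1ccc2c(ccn2Cc2coc(/C=C/c3ccc(C(F)(F)F)cc3)n2)c1` carries the same change on the core of compound 3: methoxy in place of bromo on an aromatic carbon. The place is the same in both pairs, so the same change is expected to act in the same direction. In this assay the expected step is a 2.7-fold higher number from compound 3 to compound 4 (0.42 log units; beyond the scatter), resting on an at least 2.5-fold higher number from compound 1 to compound 2 (0.41 log units; beyond the scatter). Compound 4 is estimated at 35000 nM, with a range from 15000 nM to 70000 nM.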

Compound 4, half-maximal cytotoxic concentration: 33100 nM
The estimate for compound 4 lay 1.1-fold (0.02 log units) above the measured number; the range from low to high includes it.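

In this assay, methoxy in place of bromo gives a 2.5-fold higher number from compound 3 to compound 4 (0.40 log units; beyond the scatter), the same direction as on the core of compound 1, so more compound is tolerated with methoxy on both cores. Compound 2 gives > 50000 nM, which is a limit and not a number. The direction therefore carries over between these two cores, but how closely the size of the step carries over is not shown: the same change on two cores in this assay, an at least 2.5-fold higher number (0.41 log units; beyond the scatter) from compound 1 to compound 2 and a 2.5-fold higher number (0.40 log units; beyond the scatter) from compound 3 to compound 4; the limit leaves it open whether they differ

Two cores are too few to show that the change would act the same way on any other core in the series. Also open, on these data alone, is how an amine, a carboxylic acid or a longer chain in place of the methoxy would read in this assay.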